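Working notes: fluoro in place of trifluoromethyl

The compounds below may be only part of what the source reports. "The series", "measured", "known", "first", "only" and "open" are said of these compounds alone.

Measured so far in an ADME assay on HepG2 cells (Homo sapiens) for cytotoxicity, read by luminescence, with a stated time of 72 h; on this read-out higher numbers stand for an effect only at larger amounts of compound and lower numbers for an effect already at smaller amounts:
- compound 1 `CCOC(=O)c1c(-c2cccc(OCC(C)C)c2)[nH]c2cc(OC)ccc2c1=O`: > 21500 nM (a limit)
- compound 2 `CCOC(=O)c1c(-c2cccc(OC(F)(F)F)c2)[nH]c2cc(OC)ccc2c1=O`: > 21500 nM (a limit)
- compound 3 `CCOC(=O)c1c(-c2cccc(C(F)(F)F)c2)[nH]c2cc(OC)ccc2c1=O`: > 21500 nM (a limit)

Compound 3 stands at the limit of > 21500 nM in this assay, at which 3 of the 3 values shown sit. No number is available for it, only that limit.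

The next step leads to compound 4 `CCOC(=O)c1c(-c2cccc(F)c2)[nH]c2cc(OC)ccc2c1=O` and is fluoro in place of trifluoromethyl on an aromatic carbon, meta to a large group.

Among the compounds with values here, three measured steps bear on this change: a step that the two limits leave unreadable from compound 2 to compound 3, a step that the two limits leave unreadable from compound 1 to compound 3 and a step that the two limits leave unreadable from compound 1 to compound 2. None of them has a readable size, so they offer no measured size to carry over. Within the data shown here, they show only that compounds 1, 2 and 3, which differ in this one group, all end at a limit, and none of the three goes against that.

The expectation rests on compound 3, whose value > 21500 nM is a limit. A report of a limit is also the likely outcome for compound 4 in this assay, with no readable step in either direction. The expected step is a step that the limit leaves unreadable from compound 3 to compound 4. The estimate for compound 4 is 25000 nM, with an expected range of 14000 nM to 45000 nM.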

Compound 4, half-maximal effective concentration: > 21500 nM
Compound 4: a limit, no number; the forecaster's own chance of this, stated with the estimate: 85%; the middle value does not contradict the limit.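

In this assay compound 4 gives > 21500 nM as a limit and not a number. No step among compound 1, compound 2, compound 3 and compound 4 can be read, since all of them end at the same limit: the limit of > 21500 nM in this assay, at which 4 of the 4 values shown sit.

The compounds shown leave open whether changing this one group shifts the read-out in this assay at all.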